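The compounds below may be only part of what the source reports. "The series", "measured", "known", "first", "only" and "open" are said of these compounds alone.

Series notes, step from compound 3 to compound 4.

Three compounds sharing one core have been run in an ADME assay on HEK293 cells (Homo sapiens) for cytotoxicity, read by MTT assay, with a stated time of 68 h; on this read-out lower numbers stand for stronger inhibition and higher numbers for weaker inhibition. Compound 1 `O=C(/C=C/c1cccc(OCc2ccccc2)c1)c1ccc(Br)cc1` gives 5400 nM. Compound 2 `COc1ccc(C(=O)/C=C/c2cccc(OCc3ccccc3)c2)cc1` gives 79800 nM. Compound 3 `O=C(/C=C/c1cccc(OCc2ccccc2)c1)c1cccc(Br)c1` gives 7100 nM, the second highest of the three numbers; its nearest neighbour is compound 1, its furthest compound 2.

The measured steps separate two kinds of change. Moving the bromo around the ring is quiet: a 1.3-fold higher number from compound 1 to compound 3 (0.12 log units; within the scatter). Exchanging the halogen for methoxy is not: a 15-fold higher number from compound 1 to compound 2 (1.17 log units; beyond the scatter), and in the other direction an 11-fold lower number from compound 2 to compound 3 (1.05 log units; beyond the scatter).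

Compound 4 `O=C(/C=C/c1cccc(OCc2ccccc2)c1)c1ccc(Cl)cc1` is still to be measured in this assay. It differs from compound 3 in one place: 4-chlorophenyl in place of 3-bromophenyl on a carbonyl carbon. This change has two parts. The return from the 3-position to the 4-position has a direct precedent in the step from compound 1 to compound 3, which stayed within the scatter. Among the compounds with values here, the swap of bromo for chloro has no precedent in the three numbers; the only substituent exchange measured, bromo to methoxy, was large, but a halogen-for-halogen swap is a different kind of change, and nothing argues for a shift beyond the scatter. The expected step is therefore small: a 1.1-fold lower number from compound 3 to compound 4 (0.04 log units; within the scatter).

Compound 4 is estimated at 6500 nM in this assay, with a range from 3000 nM to 16000 nM.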

Compound 4, half-maximal inhibitory concentration: 22800 nM
For compound 4 the middle estimate is 3.5-fold (0.55 log units) below the measured one, outside the stated range (above it).
By their numbers in this assay, from the lowest: compounds 1 and 3 (each within the scatter of the next); then compound 4; then compound 2.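

In this assay the halogen itself proves to matter on the aromatic ring attached to the carbonyl carbon: the first halogen-for-halogen swap gives a 4.2-fold higher number from compound 1 to compound 4 (0.63 log units; beyond the scatter), so chloro in place of bromo is not a quiet exchange in this series. Chloro also takes an intermediate place between bromo and methoxy among compounds 1, 4 and 2, since a 3.5-fold lower number from compound 2 to compound 4 (0.54 log units; beyond the scatter), a smaller step than the one between the bromo and methoxy compounds. The combined change gives a 3.2-fold higher number from compound 3 to compound 4 (0.51 log units; beyond the scatter), whereas moving the bromo alone gave a 1.3-fold higher number from compound 1 to compound 3 (0.12 log units; within the scatter), and no measured property of these compounds bears on the difference between the halogens.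

Within the data shown here, whether the chloro-for-bromo step keeps its size when the halogen stands where it does in the 3-bromophenyl of compound 3 remains open, as the position change and the halogen swap have been read together in only one step. Also open, going by these compounds, is where a trifluoromethyl group or an amine in place of the halogen would fall relative to the chloro and methoxy compounds.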